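Swapping the Benzyl Group on Compound 1 for a Sulfonyl

The source may hold more compounds than are shown below. What is called first, only, known or untested is meant among the compounds shown, and "the series" means these compounds.

Compound 1, `COc1ccc(-c2cc(=O)c3c(OC)cc(OC)cc3n2Cc2ccccc2)cc1`, was examined in an ADME assay on BJ cells (Homo sapiens) for antiproliferative activity, with a stated time of 72 h; on this read-out higher numbers stand for an effect only at larger amounts of compound and lower numbers for an effect already at smaller amounts. In this assay compound 1 gives only a limit of > 34400 nM, so no number is known for it; it sits at the limit of > 34400 nM in this assay, at which 1 of the 3 values shown sits. Compound 3, `COC(=O)c1cc(=O)c2cc(N)ccc2[nH]1`, likewise gives only a limit of > 67200 nM in this assay, at the limit of > 67200 nM in this assay, at which 1 of the 3 values shown sits. Compound 2, `COc1ccc(-c2c(Br)c(=O)c3c(OC)cc(OC)cc3n2S(=O)(=O)c2ccc(OC)cc2)cc1`, which carries a sulfonyl on the aromatic nitrogen and a bromine on the core, gives 49700 nM in this assay, a number close to the upper reach of the measurement.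

Compound 4, `COc1ccc(-c2cc(=O)c3c(OC)cc(OC)cc3n2S(=O)(=O)c2ccc(Br)cc2)cc1`, is not yet measured. It differs from compound 1 by (4-bromophenyl)sulfonyl in place of benzyl on an aromatic nitrogen. Among the measured compounds shown here, with no measured pair isolating this change, the expected step from compound 1 to compound 4 is modest and uncertain; given that compound 1 offers only a limit, compound 4 is expected either to stay at a limit or to give a weak number near that of compound 2. Compound 4 is therefore estimated at 45000 nM, with a likely span from 20000 nM to 90000 nM, the implied step being a step that the limit leaves unreadable from compound 1 to compound 4.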

Compound 4, half-maximal effective concentration: > 86200 nM
Compound 4 was reported as a limit; the forecaster's own chance of this, stated with the estimate: 50%; middle value at least 1.9-fold (0.28 log units) from the limit.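

Among the compounds shown here, compound 4 gives only a limit of > 86200 nM in this assay; with compound 1 also at a limit there, no step between compound 1 and compound 4 can be read. The compounds shown leave open whether (4-bromophenyl)sulfonyl in place of benzyl on the aromatic nitrogen changes the half-maximal effective concentration at all.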